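A few compounds are considered here, and "the series" means these few. Any claim that something is new, unique, unknown or untested is made for them only; others in the source may bear on it.

Measured so far:
compound 1 `CCCn1c(-c2ccc(O)cc2)c(C)c2ccccc21` — > 20000 nM
compound 2 `CCCn1c(-c2ccc(O)cc2)c(C)c2cc(O)ccc21` — 7900 nM

Of the compounds shown here, two sharing one core have been measured in a functional assay on HeLa cells (Homo sapiens) for inhibition, read by trypan blue exclusion, with a stated time of 72 h; a lower number here means a stronger inhibitor of growth, a higher number a weaker inhibitor of growth. Compound 1 `CCCn1c(-c2ccc(O)cc2)c(C)c2ccccc21` gives > 20000 nM, which is a limit of the assay rather than a number. Within the data shown here, compound 2 `CCCn1c(-c2ccc(O)cc2)c(C)c2cc(O)ccc21` gives 7900 nM in this assay, the only real number among the two values. The other value, that of compound 1, is a limit (the limit of > 20000 nM in this assay, at which 1 of the 2 values shown sits). The step of an at least 2.5-fold lower number from compound 1 to compound 2 (0.40 log units; beyond the scatter) came from a single change: hydroxy in place of hydrogen on an aromatic carbon.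

Compound 3 `CCCn1c(-c2ccc(O)c(O)c2)c(C)c2cc(O)ccc21` has not yet been measured in this assay. It differs from compound 2 by hydroxy in place of hydrogen on an aromatic carbon. Among the measured compounds shown here, the one measured step that bears on this change is an at least 2.5-fold lower number from compound 1 to compound 2 (0.40 log units; beyond the scatter), the same kind of change, a hydroxy entering where a hydrogen sat, though on a different ring. That step went beyond the scatter toward a lower number, so a second hydroxy is expected to move this assay in the same direction, by a modest amount at most. The step of a 2.0-fold lower number from compound 2 to compound 3 (0.30 log units; within the scatter) is therefore the estimate. For compound 3 the expected value in this assay is 4000 nM, in the range 1500 nM to 12000 nM.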

Compound 3, concentration for 50% growth inhibition: > 20000 nM
Compound 3 was reported as a limit; the forecaster's own chance of this, stated with the estimate: 10%; middle value at least 5.0-fold (0.69 log units) from the limit.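

The same change, hydroxy in place of hydrogen on an aromatic carbon, does not act the same way at both places in this assay. It gave an at least 2.5-fold lower number from compound 1 to compound 2 (0.40 log units; beyond the scatter), whereas at the new place, ortho to a hydroxy group and meta to a large group, it gave an at least 2.5-fold higher number from compound 2 to compound 3 (0.40 log units; beyond the scatter), so in these compounds the direction of the step depends on where the hydroxy enters. The result for compound 3 is a limit and not a number, so the true size of this loss of growth inhibition cannot be read, and only compound 2 keeps a real value: the limit of > 20000 nM in this assay, at which 2 of the 3 values shown sit.

The compounds shown leave open whether the loss belongs to the hydroxy itself or would also follow a methoxy, a fluorine or an amine at this place. They also leave open whether a hydroxy at this place would still weaken growth inhibition on the core of compound 1, which lacks the hydroxy that compound 2 gained, although a compound already at the limit could show only a gain.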